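The compounds below may be only part of what the source reports. "The series", "measured", "known", "first", "only" and "open" are said of these compounds alone.

Measured compounds:
compound 1 `FC(F)(F)Oc1cc2[nH]ncc2cc1-c1ccccc1C(F)(F)F`, 36 nM
compound 2 `N#Cc1cc2[nH]ncc2cc1-c1ccccc1C(F)(F)F`, 129 nM

Among the measured compounds shown here, compound 2 holds the highest number of the two in an assay on CHO-TREX cells for antagonist activity at transient receptor potential cation channel subfamily A member 1 (Homo sapiens), read by FLIPR and calcium flux, with a stated time of 10 min; a lower number here means a stronger inhibitor, a higher number a weaker inhibitor; compound 1 sits at 36 nM, and the single step across the pair, a 3.6-fold higher number from compound 1 to compound 2 (0.55 log units; beyond the scatter), lies beyond the scatter. Compound 3 `CNC(=O)c1cc2[nH]ncc2cc1-c1ccccc1C(F)(F)F` follows from compound 2 by methylcarbamoyl in place of cyano on an aromatic carbon. For the measured compounds named here, no measured step involves the methylcarbamoyl group, so the one step above bears only loosely: it shows that exchanging the group on the same aromatic carbon shifts the number modestly. For compound 3 a modest step is expected, most likely toward a somewhat higher number, a 1.7-fold higher number from compound 2 to compound 3 (0.23 log units; within the scatter). Compound 3 is estimated at 220 nM, range 50 nM to 900 nM.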

Compound 3, half-maximal inhibitory concentration: > 30000 nM
Compound 3: no number, only a limit; the forecaster's own chance of this, stated with the estimate: 5%; middle value at least 130-fold (2.13 log units) from the limit.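

In this assay compound 3 gives > 30000 nM, which is a limit of the assay and not a number. Methylcarbamoyl in place of cyano brings an at least 230-fold higher number from compound 2 to compound 3 (2.36 log units; beyond the scatter), and methylcarbamoyl in place of trifluoromethoxy brings an at least 830-fold higher number from compound 1 to compound 3 (2.92 log units; beyond the scatter). The earlier exchange at this aromatic carbon, ortho to a large group, was a modest step, whereas both steps to methylcarbamoyl are large, so this position does not tolerate every exchange equally.

The compounds shown do not separate the hydrogen-bond donor of methylcarbamoyl from its larger size. A dimethylcarbamoyl or methoxy group on the same carbon would bear on that question.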